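Bromo for fluoro at a shared assay limit

The source may report more compounds than this note shows. Statements on the series, on what has been measured and on what is new or still open speak of the compounds shown alone.

Compound 1 `Fc1cccc(-c2nc(Nc3ccccc3)c3ccccc3n2)c1`, compound 2 `Fc1ccc2nc(-c3ccccc3)nc(Nc3ccccc3)c2c1` and compound 3 `Fc1cccc(-c2nc(Nc3ccccc3F)c3cc(F)ccc3n2)c1` share one core and differ only in where their fluorines sit. In a functional assay on HL-60 cells (Homo sapiens) for cytotoxicity, read by MTT assay, with a stated time of 48 h (on this read-out higher numbers stand for weaker inhibition and lower numbers for stronger inhibition), compound 1 gives only a limit, > 50000 nM. Compound 2 likewise reaches only a limit in this assay, > 50000 nM. Compound 3 stands at the same limit in this assay, > 50000 nM. For the measured compounds named here, all three values therefore sit together (the limit of > 50000 nM in this assay, at which 3 of the 3 values shown sit), and no measured step exists among them. Compound 4 `Fc1cccc(-c2nc(Nc3ccccc3Br)c3cc(F)ccc3n2)c1`, not yet measured, differs from compound 3 by bromo in place of fluoro on an aromatic carbon, ortho to a large group. Going by the values given here, with no step measured, the expected change in this assay is none beyond the scatter, a number no higher from compound 3 to compound 4 (the limit leaves the size open). Compound 4 is thus estimated at 50000 nM in this assay, within 20000 nM to 100000 nM, most likely again reported only as a limit.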

Compound 4, half-maximal inhibitory concentration: > 50000 nM
Compound 4: no number, only a limit; the forecaster's own chance of this, stated with the estimate: 80%; the middle value sits exactly at the limit.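

No step can be read between compound 3 and compound 4, as both give only a limit: the limit of > 50000 nM in this assay, at which 4 of the 4 values shown sit.

The compounds shown leave open how far any of them lies beyond that limit in this assay.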